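Methyl in place of hydrogen on the amino acid carbon

The source may report more compounds than this note shows. Statements on the series, on what has been measured and on what is new or still open speak of the compounds shown alone.

Measured so far:
compound 1 `C[C@@H](N)C(=O)NCc1nnc(-c2ccccc2)o1` — 98 nM
compound 2 `NCC(=O)NCc1nnc(-c2ccc(F)cc2)o1` — 135 nM

In an assay for inhibition of histone deacetylase 8 (Homo sapiens), read by fluorescence, with a stated time of 15 min (on this read-out lower numbers stand for stronger inhibition and higher numbers for weaker inhibition), compound 2 gives 135 nM, the highest of the two numbers; compound 1 gives 98 nM, a number lower by an amount within the scatter, so the two values show no separation. Compound 3 `C[C@@H](N)C(=O)NCc1nnc(-c2ccc(F)cc2)o1` differs from compound 2 by methyl in place of hydrogen on a saturated chain carbon bound to an amine nitrogen and a carbonyl carbon. Within the data shown here, no step between measured compounds covers this change, so only the values of compound 1 and compound 2 inform the expectation. For compound 3 the expected step of a 1.5-fold lower number from compound 2 to compound 3 (0.18 log units; within the scatter) is small, at most a slight lowering, not beyond the scatter. Compound 3 is estimated at 90 nM, within 40 nM to 200 nM.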

Compound 3, half-maximal inhibitory concentration: 116 nM
For compound 3 the middle estimate is 1.3-fold (0.11 log units) below the measured one, within the range that was stated.
By their numbers in this assay, from the lowest: compounds 1, 3 and 2 (each within the scatter of the next).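

In this assay, methyl in place of hydrogen on a saturated chain carbon bound to an amine nitrogen and a carbonyl carbon gives a 1.2-fold lower number from compound 2 to compound 3 (0.07 log units; within the scatter) and so leaves the two compounds unseparated at this position. Fluoro in place of hydrogen on an aromatic carbon, now readable as a single change, gives a 1.2-fold higher number from compound 1 to compound 3 (0.07 log units; within the scatter) and likewise shows no separation. Nothing available bears on the reason for either result.

Still open, as far as these compounds go, is whether isopropyl or benzyl on this chain carbon would give a step beyond the scatter. Also open, from the compounds shown here alone, is whether chloro or methoxy in place of fluoro would do so.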